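The source may report more compounds than this note shows. Statements on the series, on what has been measured and on what is new or still open speak of the compounds shown alone.

In a functional assay on MDA-MB-231 cells (Homo sapiens) for antiproliferative activity, read by MTT assay, with a stated time of 72 h (on this read-out higher numbers stand for weaker inhibition and lower numbers for stronger inhibition), compound 2 (`NC1=NC2(CCSCC2)N(OCCCOc2cc(Cl)c(Cl)cc2Cl)C(N)=N1`) stands at 110 nM and compound 1 (`NC1=NC2(CCSCC2)N(OCCCOc2cccc(Cl)c2)C(N)=N1`) at 130 nM within the scatter of each other, while compound 3 (`NC1=NC2(CCOCC2)N(OCCCOc2cccc(Br)c2)C(N)=N1`) gives 400 nM as a number higher than that of compound 2 beyond the scatter. Compound 4 (`NC1=NC2(CCSCC2)N(OCCCOc2cccc(Br)c2)C(N)=N1`) is still unmeasured and differs from compound 2 by one change (3-bromophenyl in place of 2,4,5-trichlorophenyl on an oxygen on a saturated carbon), with 3-bromophenyl in place of 2,4,5-trichlorophenyl on an oxygen on a saturated carbon. Within the data shown here, the only measured step at this place (a 1.2-fold lower number from compound 1 to compound 2 (0.07 log units; within the scatter)) stayed within the scatter, so no change beyond the scatter is expected in this assay here. The estimated step is small (a 1.2-fold higher number from compound 2 to compound 4 (0.07 log units; within the scatter)). For compound 4 the estimate is 130 nM (expected range 60 nM to 280 nM).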

Compound 4, half-maximal inhibitory concentration: 60 nM
Beside the measured number, compound 4's estimate is 2.2-fold (0.34 log units) above it; measured number inside the range.
By their numbers in this assay, from the lowest: compounds 4, 2 and 1 (each within the scatter of the next, the first and the last beyond it); then compound 3.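

In this assay, the aryl group on the oxygen now gives a step beyond the scatter, though a modest one: a 2.2-fold lower number from compound 1 to compound 4 (0.34 log units; beyond the scatter), with bromo in place of chloro on an aromatic carbon. By contrast, a 1.8-fold lower number from compound 2 to compound 4 (0.26 log units; within the scatter) stays within the scatter, so 3-bromophenyl and 2,4,5-trichlorophenyl cannot be ordered. Nothing available explains the bromo step. Still open, on these data alone, is whether iodo or fluoro in place of bromo would extend or reverse this step. Also open, as far as these compounds go, is how an amine or a carboxylic acid on the phenyl ring would read in this assay.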